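Dimethylamino for hydroxy on a sulfamate amide chain

The source may report more compounds than this note shows. Statements on the series, on what has been measured and on what is new or still open speak of the compounds shown alone.

Three compounds with a shared sulfamate core were examined in an assay on HEK293 cells for inhibition of Steryl-sulfatase (Homo sapiens), tested at 0.1 uM; on this read-out lower numbers stand for a weaker effect and higher numbers for a stronger effect at the one concentration tested. Compound 1 `CN(C)CCCN(Cc1ccccc1)c1cccc(C(=O)N2CCc3ccc(OS(N)(=O)=O)cc3C2)c1` gives 23.8% in this assay. Compound 3 `NS(=O)(=O)Oc1ccc2c(c1)CN(C(=O)c1ccc(N3CCC(Cc4ccccc4)CC3)cc1)CC2` gives 41.4% in this assay. Compound 2 `NS(=O)(=O)Oc1ccc2c(c1)CN(C(=O)c1ccc(N(CCCO)Cc3ccccc3)cc1)CC2` gives 5.7% in this assay, the lowest of the three numbers: compound 1 sits higher by a margin beyond the scatter, and compound 3 sits further above it, again beyond the scatter.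

Compound 4 `CN(C)CCCN(Cc1ccccc1)c1ccc(C(=O)N2CCc3ccc(OS(N)(=O)=O)cc3C2)cc1` has not yet been measured in this assay. It differs from compound 2 in one place: dimethylamino in place of hydroxy on a saturated chain carbon, three bonds along the chain from a nitrogen on an aromatic ring. Compound 1, which also bears a 3-(dimethylamino)propyl chain, reaches 23.8% in this assay, and no other pairing among the measured compounds bears on this change.

Because compound 1 with its 3-(dimethylamino)propyl chain gives 23.8% while compound 2 with its 3-hydroxypropyl chain gives 5.7%, the account expects the step of a number 14.3 percentage points higher from compound 2 to compound 4 (beyond the scatter) to run upward and to go somewhat beyond the scatter. The estimate for compound 4 in this assay is 20%, with a range from 5% to 38%, and the measurement will show whether that expectation holds.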

Compound 4, a percentage reported as inhibition, at one concentration (the size of the read-out at that concentration, not a potency): 16.2%
Compound 4: the middle estimate sits 3.8 percentage points above what was measured; the range from low to high includes it.
By their numbers in this assay, from the lowest: compound 2; then compounds 4 and 1 (each within the scatter of the next); then compound 3.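

Among these compounds, the pairing gives the first direct reading of this change: with dimethylamino in place of hydroxy on a saturated chain carbon, three bonds along the chain from a nitrogen on an aromatic ring, this assay shows a number 10.5 percentage points higher from compound 2 to compound 4 (beyond the scatter). The step is modest, yet it shows that this position accepts the group of 3 heavy atoms in place of the group of 1 heavy atom, and the loss of the hydrogen-bond donor, without a fall in the number. Nothing measured here explains why the number moves with this change.

The compounds shown leave open whether the end of the chain prefers other groups, such as a primary amine, a morpholine or a carboxylic acid, and whether a longer chain bearing dimethylamino would carry the number further. They also leave open whether this step would hold as a difference in potency, since the read-out comes from a single concentration and rests on one pair of compounds.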